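A Hydrazone Aryl Swap Within a Shared Core

The source may hold more compounds than are shown below. What is called first, only, known or untested is meant among the compounds shown, and "the series" means these compounds.

Measured so far in a functional assay on MDA-MB-231 cells (Homo sapiens) for cytotoxicity, read by MTT assay, with a stated time of 72 h; a lower number here means a stronger inhibitor, a higher number a weaker inhibitor:
compound 1, `COc1cc2c(Oc3ccc(NC(=O)N/N=C/c4ccc(F)cc4Cl)cc3F)ccnc2cc1OCCCN1CCCCC1`, gives 790 nM
compound 2, `COc1cc2c(Oc3ccc(NC(=O)N/N=C/c4ccc(Cl)cc4Cl)cc3F)ccnc2cc1OCCCN1CCCCC1`, gives 750 nM
compound 3, `COc1cc2c(Oc3ccc(NC(=O)N/N=C/c4ccncc4)cc3F)ccnc2cc1OCCCN1CCCCC1`, gives 1400 nM

These three compounds share one core and differ only in the aromatic group on the carbon with a double bond to nitrogen. Compound 3 has the highest of the three numbers, yet the two steps that lead to it (a 1.8-fold higher number from compound 1 to compound 3 (0.25 log units; within the scatter) and a 1.9-fold higher number from compound 2 to compound 3 (0.27 log units; within the scatter)) both lie within the scatter, so no ordering can be read from them. The exchange of halogens between compound 1 and compound 2 (a 1.1-fold lower number from compound 1 to compound 2 (0.02 log units; within the scatter)) is likewise within the scatter.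

Compound 4, `COc1cc2c(Oc3ccc(NC(=S)N/N=C/c4ccc(Cl)cc4)cc3F)ccnc2cc1OCCCN1CCCCC1`, has not yet been measured. Relative to compound 3 the change is a group of 12 heavy atoms (8 carbon, 2 nitrogen, 1 sulfur, 1 chlorine; one six-membered aromatic ring of carbon only) in place of a group of 11 heavy atoms (7 carbon, 3 nitrogen, 1 oxygen; one six-membered aromatic ring with 1 hetero atom), on a nitrogen on an aromatic ring. In effect the ring with one hetero atom gives way to a carbon-only aromatic ring bearing chlorine, as in compounds 1 and 2, while the carbonyl becomes a thiocarbonyl. For the measured compounds named here, the steps that bear on this are the two that introduced the pyridine ring, from compound 1 to compound 3 and from compound 2 to compound 3; both were small. Reversing that kind of change should therefore give at most a small step, and nothing among the measured compounds speaks to the oxygen-to-sulfur swap. For compound 4 the expected step is a 1.6-fold lower number from compound 3 to compound 4 (0.22 log units; within the scatter), within the scatter. Compound 4 is estimated at 850 nM, with a range from 350 nM to 2100 nM.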

Compound 4, half-maximal inhibitory concentration: 1300 nM
Estimate against measurement, compound 4: 1.5-fold (0.18 log units) below, and the stated range covers the measured number.
By their numbers in this assay, from the lowest: compounds 2, 1, 4 and 3 (each within the scatter of the next).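

In this assay, the exchange on a nitrogen on an aromatic ring gives a 1.1-fold lower number from compound 3 to compound 4 (0.03 log units; within the scatter) and so stays small even though two things change in one group: the ring with one hetero atom gives way to a carbon-only aromatic ring bearing chlorine, and the carbonyl becomes a thiocarbonyl. Compound 4 is the only compound shown with a thiocarbonyl, and it shows that this combined exchange brings no step beyond the scatter, although the two parts cannot be told apart, as each might do little or they might offset each other. No measured property of these groups bears on the result, so nothing can be said about what lies behind it.

A thiocarbonyl paired with the pyridin-4-yl ring, or a carbonyl paired with the same chlorine-bearing ring as compound 4, would separate the two parts, but the compounds shown include neither. For the compounds shown here, every step so far lies within the scatter, and whether an amine or a carboxylic acid on that aromatic ring would move the number further remains open.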